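The source may report more compounds than this note shows. Statements on the series, on what has been measured and on what is new or still open speak of the compounds shown alone.

Compound 1 `CCc1nc2ccc(-n3ccc(OCc4ccc(F)cc4)cc3=O)cc2n1C`: 38 nM
Compound 2 `Cn1c(C2CC2)nc2ccc(-n3ccc(OCc4ccc(F)cc4)cc3=O)cc21`: 28 nM
Compound 3 `Cn1c(C2CCC2)nc2ccc(-n3ccc(OCc4ccc(F)cc4)cc3=O)cc21`: 210 nM

In an assay on CHO cells for displacement of a labelled ligand from melanin-concentrating hormone receptor 1 (Rattus norvegicus), read by scintillation counting, with a stated time of 1 h (on this read-out higher numbers stand for weaker inhibition and lower numbers for stronger inhibition), compound 2 gives 28 nM. Compound 1 stands within the scatter of it, as a 1.4-fold lower number from compound 1 to compound 2 (0.13 log units; within the scatter) shows, while compound 3 lies beyond it, a 7.5-fold higher number from compound 2 to compound 3 (0.88 log units; beyond the scatter). Compound 4 `Cn1c(C2CC2)nc2ccc(-n3ccc(OCc4csc(Cl)c4)cc3=O)cc21` differs from compound 2 by 5-chlorothiophen-3-yl in place of 4-fluorophenyl on a saturated chain carbon bound to an oxygen on an aromatic ring. Among the compounds with values here, none of the measured steps touches this place: a 1.4-fold lower number from compound 1 to compound 2 (0.13 log units; within the scatter), a 5.5-fold higher number from compound 1 to compound 3 (0.74 log units; beyond the scatter) and a 7.5-fold higher number from compound 2 to compound 3 (0.88 log units; beyond the scatter) all concern the group on the aromatic carbon of the shared core. The data therefore give no direct guide to this change, and nothing beyond a modest step in either direction is expected in this assay. Compound 4 is estimated at 40 nM, between 12 nM and 130 nM, which would mean an expected step of a 1.4-fold higher number from compound 2 to compound 4 (0.15 log units; within the scatter).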

Compound 4, half-maximal inhibitory concentration: 9.3 nM
For compound 4 the middle estimate is 4.3-fold (0.63 log units) above the measured one, outside the stated range (below it).
By their numbers in this assay, from the lowest: compound 4; then compounds 2 and 1 (each within the scatter of the next); then compound 3.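

In this assay, within the data shown here, the group on a saturated chain carbon bound to an oxygen on an aromatic ring can also move the number, whereas the earlier steps concerned only the group on the aromatic carbon of the shared core. With cyclopropyl kept, 5-chlorothiophen-3-yl in place of 4-fluorophenyl gives a step beyond the scatter (a 3.0-fold lower number from compound 2 to compound 4 (0.48 log units; beyond the scatter)), so a five-membered aromatic ring with one hetero atom is accepted here. No measured evidence accounts for this gain. As far as these compounds go, whether the chlorine alone carries the step stays open, as does how an unsubstituted phenyl or a 4-chlorophenyl would read at this place.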